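The compounds below may be only part of what the source reports. "The series", "measured", "known", "first", "only" and "open" are said of these compounds alone.

Measured compounds:

Compound 1 `COc1ccc(-c2ccc(C)n2-c2ccc(-c3nc4ccc(F)cc4s3)cc2)cc1` gives 2120 nM in a functional assay on MCF7 cells (Homo sapiens) for cytotoxicity, read by sulforhodamine B assay, with a stated time of 48 h; on this read-out lower numbers stand for stronger inhibition of growth and higher numbers for weaker inhibition of growth.
Compound 2 `Cc1ccc(-c2ccc([N+](=O)[O-])cc2)n1-c1ccc(-c2nc3ccc(F)cc3s2)cc1` gives 918 nM in this assay.
Compound 3 `COc1ccc(-c2ccc(C)n2-c2ccc(-c3nc4ccc(OC)cc4s3)cc2)cc1` gives 3090 nM in this assay.

Compound 4 `COc1ccc2nc(-c3ccc(-n4c(C)ccc4-c4ccc([N+](=O)[O-])cc4)cc3)sc2c1` is not yet measured. It differs from compound 3 by nitro in place of methoxy on an aromatic carbon. The same change separates compound 1 from compound 2, where it reads (nitro in place of methoxy on an aromatic carbon), and there it gave a 2.3-fold lower number from compound 1 to compound 2 (0.36 log units; beyond the scatter). The two cores differ by methoxy in place of fluoro on an aromatic carbon, a change that gave a 1.5-fold higher number from compound 1 to compound 3 (0.16 log units; within the scatter). Going by the values given here, with only one earlier example of the change, and on a core that differs in this one place, the expectation for compound 4 is that it follows compound 2 in direction, moving from compound 3 by an estimated 2.3-fold lower number from compound 3 to compound 4 (0.36 log units; beyond the scatter), because compound 2 showed a 2.3-fold lower number from compound 1 to compound 2 (0.36 log units; beyond the scatter). Compound 4 is therefore estimated at 1350 nM in this assay, expected to lie between 700 nM and 2700 nM.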

Compound 4, concentration for 50% growth inhibition: 3170 nM
The estimate for compound 4 lay 2.3-fold (0.37 log units) below the measured number; the measured number lies above the stated range.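

In this assay, nitro in place of methoxy on the core of compound 3 gave a 1.0-fold higher number from compound 3 to compound 4 (0.01 log units; within the scatter), while methoxy in place of fluoro on the core of compound 2 gave a 3.5-fold higher number from compound 2 to compound 4 (0.54 log units; beyond the scatter). The nitro change therefore reads beyond the scatter on one core and within it on the other, yet the two steps cannot be told apart: the same change on two cores in this assay, a 2.3-fold lower number (0.36 log units; beyond the scatter) from compound 1 to compound 2 and a 1.0-fold higher number (0.01 log units; within the scatter) from compound 3 to compound 4, 2.4-fold (0.37 log units) apart, within the scatter of two such steps. Going by these compounds alone, the methoxy change shows the same picture, so with only two examples of each change, these data neither prove that a change carries over between cores nor prove that it fails to: the same change on two cores in this assay, a 1.5-fold higher number (0.16 log units; within the scatter) from compound 1 to compound 3 and a 3.5-fold higher number (0.54 log units; beyond the scatter) from compound 2 to compound 4, 2.4-fold (0.37 log units) apart, within the scatter of two such steps.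

The compounds shown leave open how an amine or a carboxylic acid would read in place of the nitro or methoxy group.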